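A few compounds are considered here, and "the series" means these few. Any claim that something is new, unique, unknown or untested is made for them only; others in the source may bear on it.

Compound 3 `Cc1ccc(C2=NOC(c3c[nH]c4ccccc34)C2CN2CCCCC2)cc1` gives 51.5% in a functional assay on the whole organism (strain Wistar) for inhibition, with Rattus norvegicus as the target, read by paw edema, with stated times of 1 h and 4 h, at a dose of 70 mg/kg by the oral route (a higher number here means more inhibition at the dose given (going by the name of the read-out), a lower number less inhibition), and its number lies within the scatter of both other values in the set. Compound 2 `Clc1ccc(C2=NOC(c3c[nH]c4ccccc34)C2CN2CCCCC2)cc1` gives 53.5% in this assay. Compound 1 `c1ccc(C2=NOC(c3c[nH]c4ccccc34)C2CN2CCCCC2)cc1` gives 48.5% in this assay. All three differ only at the same aromatic carbon, and none of the steps among them is beyond the scatter: a number 5 percentage points higher from compound 1 to compound 2 (within the scatter), a number 3 percentage points higher from compound 1 to compound 3 (within the scatter), a number 2 percentage points lower from compound 2 to compound 3 (within the scatter). Compound 4 `COc1ccc(C2=NOC(c3c[nH]c4ccccc34)C2CN2CCCCC2)cc1` carries the change (methoxy in place of methyl on an aromatic carbon). Among the compounds with values here, no measured step covers methoxy itself. The nearest guides are the two substitutions at that carbon, which were flat, so the step in this assay for compound 4 is expected to stay within the scatter, a number 0.5 percentage points higher from compound 3 to compound 4 (within the scatter). Compound 4 is therefore estimated at 52%, with a range from 42% to 62%.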

Compound 4, a percentage reported as inhibition, in the whole organism at one dose (the size of the read-out at that dose, not a potency): 50.5%
Beside the measured number, compound 4's estimate is 1.5 percentage points above it; the range from low to high includes it.
By their numbers in this assay, from the lowest: compounds 1, 4, 3 and 2 (each within the scatter of the next).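

Methoxy brings the first oxygen and the first hydrogen-bond acceptor to this carbon, yet this assay still shows no step beyond the scatter: (a number 1 percentage points lower from compound 3 to compound 4 (within the scatter)) and (a number 3 percentage points lower from compound 2 to compound 4 (within the scatter)) and (a number 2 percentage points higher from compound 1 to compound 4 (within the scatter)). Hydrogen, chloro, methyl and methoxy at this carbon therefore cannot be told apart in this read-out. Nothing available bears on why the change from 4-methylphenyl to 4-methoxyphenyl leaves the number unmoved. Open, as far as these compounds go, is whether an amine, a carboxylic acid or a longer chain at this carbon would give a step beyond the scatter.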